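A few compounds are considered here, and "the series" means these few. Any claim that something is new, unique, unknown or untested is made for them only; others in the source may bear on it.

Measured compounds:
Compound 1, `CCOC(=O)c1cccc(-c2ccc(OCC)cc2)c1`: in an assay on COS-7 cells for inhibition of patatin-like phospholipase domain-containing protein 2 (Mus musculus), tested at 200 uM (on this read-out higher numbers stand for more inhibition at the one concentration tested (going by the name of the read-out) and lower numbers for less inhibition), compound 1 gives 87%.
Compound 2, `CCOC(=O)C1CCCC(c2ccc(OCC)cc2)N1`: in this assay compound 2 gives 48%.
Compound 3, `CCNS(=O)(=O)c1cccc(-c2ccc(OCC)cc2)c1`: in this assay compound 3 gives 46%.

Among these three numbers compound 3 stands lowest. Its nearest neighbour is compound 2, whose value lies within the scatter of that of compound 3, so no order between the two can be claimed. Among the measured compounds shown here, its furthest neighbour is compound 1, and the one step measured so far runs a number 41 percentage points lower from compound 1 to compound 3 (beyond the scatter), where ethylsulfamoyl stands in place of ethoxycarbonyl on an aromatic carbon.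

The next compound, compound 4 `CCOc1ccc(-c2cccc(S(=O)(=O)N(C)C)c2)cc1`, keeps the ethylsulfamoyl-bearing frame of compound 3 but alters the group on the sulfonyl sulfur: dimethylamino in place of ethylamino on a sulfonyl sulfur

For the measured compounds named here, no measured step bears directly on this exchange. Going by the values given here, the only step on record swaps the whole group on the aromatic carbon, and it was large; the present change is smaller in kind, rearranging the same atoms on the sulfonyl sulfur while removing the single hydrogen-bond donor. With nothing else to go on, the expected step is a number 2 percentage points lower from compound 3 to compound 4 (within the scatter), inside the scatter. Compound 4 is therefore estimated at about 44%, with a range from 22% to 66%.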

Compound 4, a percentage reported as inhibition, at one concentration (the size of the read-out at that concentration, not a potency): 63%
Compound 4: middle estimate off by 19 percentage points, on the low side, and the stated range covers the measured number.
By their numbers in this assay, from the lowest: compounds 3 and 2 (each within the scatter of the next); then compound 4; then compound 1.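

In this assay, the group on the sulfonyl sulfur proves to matter in its own right: dimethylamino in place of ethylamino gives a number 17 percentage points higher from compound 3 to compound 4 (beyond the scatter), although the two groups hold the same heavy atoms and differ in that ethylamino carries a hydrogen-bond donor and dimethylamino none. Among the compounds shown here, the earlier compounds showed only that exchanging the whole group on the aromatic carbon could give a number 41 percentage points lower from compound 1 to compound 3 (beyond the scatter), and the new result shows that part of that distance depends on the sulfonyl sulfur's substituent, though dimethylsulfamoyl in place of ethoxycarbonyl on an aromatic carbon still leaves a number 24 percentage points lower from compound 1 to compound 4 (beyond the scatter). Nothing available gives a reason for either of these steps.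

The compounds shown leave open whether the rise follows the loss of the hydrogen on the nitrogen or the particular arrangement of the two methyl groups, which a diethylamino, pyrrolidine or morpholine group on the sulfonyl sulfur would help to separate. They also leave open how a carboxylic acid or a dimethylamide would compare with ethoxycarbonyl on the same aromatic carbon, and, with one concentration tested, how these percentages relate to potency.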